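Isobutyl on the ring nitrogen of compound 1

A few compounds are considered here, and "the series" means these few. Any claim that something is new, unique, unknown or untested is made for them only; others in the source may bear on it.

Measured in an assay on isolated protein for agonist activity at Bile acid receptor (Homo sapiens), read by TR-FRET; a higher number here means that more compound is needed for the effect, a lower number that less compound is needed:
compound 1 `CC(C)c1onc(-c2c(Cl)cccc2Cl)c1COc1ccc(-c2nc3ccc(C(=O)O)cc3n2C(C)C)cc1` gives 56.7 nM
compound 2 `CC(C)c1onc(-c2c(Cl)cccc2Cl)c1COc1ccc(-c2nc3ccc(C(=O)O)cc3n2CC2CC2)cc1` gives 29.1 nM
compound 3 `CC(C)c1onc(-c2c(Cl)cccc2Cl)c1COc1ccc(-c2nc3ccc(C(=O)O)cc3n2C2CCC2)cc1` gives "not determined" (no result reported)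

Compound 1 stands highest of the two numbers, with compound 2 nearest: a 1.9-fold lower number from compound 1 to compound 2 (0.29 log units; within the scatter). Compound 3 adds nothing to judge against.

Compound 4 `CC(C)Cn1c(-c2ccc(OCc3c(-c4c(Cl)cccc4Cl)noc3C(C)C)cc2)nc2ccc(C(=O)O)cc21` differs from compound 1 in one place: isobutyl in place of isopropyl on an aromatic nitrogen. Within the data shown here, the only step that bears on it is the one from compound 1 to compound 2, where another group of four carbons replaced the isopropyl on the same nitrogen and the number stayed within the scatter. Compound 4 is therefore expected to sit close to compound 1, if anything a little lower: a 1.4-fold lower number from compound 1 to compound 4 (0.15 log units; within the scatter). The estimate for compound 4 in this assay is 40 nM, within 15 nM to 110 nM.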

Compound 4, half-maximal effective concentration: 24.7 nM
For compound 4 the middle estimate is 1.6-fold (0.21 log units) above the measured one, within the range that was stated.
By their numbers in this assay, from the lowest: compounds 4, 2 and 1 (each within the scatter of the next, the first and the last beyond it).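

Among these compounds, on the aromatic nitrogen, isobutyl in place of isopropyl gives the first step in this assay beyond the scatter (a 2.3-fold lower number from compound 1 to compound 4 (0.36 log units; beyond the scatter)), though a modest one. Cyclopropylmethyl and isobutyl cannot be told apart at this position (a 1.2-fold lower number from compound 2 to compound 4 (0.07 log units; within the scatter)), so the cyclopropyl ring is not required for the number seen with compound 2. No evidence on the cause of either step is available.

Open, on these data alone, is whether a longer chain, such as n-pentyl, or a chain ending in an amine or a hydroxyl, keeps this level. With no number for compound 3, the cyclobutyl group cannot be judged.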